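Fluoro for Amino on Two Related Purine-Like Cores

The compounds below may be only part of what the source reports. "The series", "measured", "known", "first", "only" and "open" are said of these compounds alone.

Measured compounds:
compound 1, `CC(=O)OC(C)n1cnc2c(Cl)nc(N)nc21`: > 500000 nM
compound 2, `CC(=O)OC(C)n1cnc2c(Cl)nc(F)nc21`: 93300 nM
compound 3, `CC(=O)OCCOn1cnc2c(S)nc(N)nc21`: > 500000 nM

In a functional assay (Homo sapiens) for inhibition (on this read-out lower numbers stand for stronger inhibition and higher numbers for weaker inhibition), compound 1 gives > 500000 nM, which is a limit of the assay and not a number. Compound 2 differs from compound 1 by fluoro in place of amino on an aromatic carbon; in this assay compound 2 gives 93300 nM, so the change brings an at least 5.3-fold lower number from compound 1 to compound 2 (0.72 log units; beyond the scatter).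

Compound 3, in this assay, gives > 500000 nM, again a limit of the assay and not a number. How the core of compound 3 differs from the core of compound 1 is not broken down here. Compound 4, `CC(=O)OCCOn1cnc2c(S)nc(F)nc21`, has not yet been measured; it differs from compound 3 by fluoro in place of amino on an aromatic carbon. The place is not the same word for word as in the first pair: there the site was meta to a chloro group, here meta to a sulfanyl group, so this is the same kind of change rather than the same change.

Resting on an at least 5.3-fold lower number from compound 1 to compound 2 (0.72 log units; beyond the scatter) and on (the limit of > 500000 nM in this assay, at which 2 of the 3 values shown sit), the step from compound 3 to compound 4 is expected to be an at least 3.3-fold lower number from compound 3 to compound 4 (0.52 log units; beyond the scatter). In this assay compound 4 is therefore estimated at 150000 nM, most likely between 30000 nM and 500000 nM.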

Compound 4, half-maximal inhibitory concentration: > 500000 nM
Compound 4 ended at the assay's limit (the forecaster's own chance of this, stated with the estimate: 35%); middle value at least 3.3-fold (0.52 log units) from the limit.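

In this assay compound 4 gives > 500000 nM as a limit of the assay and not a number. Compound 3 also stands at a limit, so the step between compound 3 and compound 4 cannot be read, and the series mostly stays there: the limit of > 500000 nM in this assay, at which 3 of the 4 values shown sit. From the compounds shown here alone, whether fluoro in place of amino changes anything on this core stays open.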